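The source may hold more compounds than are shown below. What is called first, only, known or untested is meant among the compounds shown, and "the series" means these compounds.

Of the compounds shown here, three on one shared core have been read in a physicochemical assay for solubility, in phosphate buffer, measured as kinetic solubility, at pH 7.4; on this read-out higher numbers stand for higher solubility and lower numbers for lower solubility: compound 1 `Cc1oc(-c2c(Cl)cccc2Cl)nc1CN1CCC(C(=O)NCCCN2C[C@H](C)C[C@H](C)C2)CC1`, compound 2 `COc1cccc(Br)c1-c1nc(CN2CCC(C(=O)NCCCN3C[C@H](C)C[C@H](C)C3)CC2)c(C)o1` and compound 3 `COc1cccc(Cl)c1-c1nc(CN2CCC(C(=O)NCCCN3C[C@H](C)C[C@H](C)C3)CC2)c(C)o1`. In this assay compound 1 gives > 77 ug/mL, which is a limit and not a number. Compound 2 gives > 83 ug/mL, again a limit. Compound 3 gives > 76 ug/mL, also a limit, so compound 3 has no exact number to stand on.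

Compound 4 `Cc1ccc(-c2nc(CN3CCC(C(=O)NCCCN4C[C@H](C)C[C@H](C)C4)CC3)c(C)o2)c(C)c1` differs from compound 3 in one place, where 2,4-dimethylphenyl takes the place of 2-chloro-6-methoxyphenyl on an aromatic carbon: 2,4-dimethylphenyl in place of 2-chloro-6-methoxyphenyl on an aromatic carbon.

Within the data shown here, three measured steps bear on this, since each changes the group at that same place: a step that the two limits leave unreadable from compound 1 to compound 2, a step that the two limits leave unreadable from compound 1 to compound 3 and a step that the two limits leave unreadable from compound 2 to compound 3. None of them has a readable size, and none brings in 2,4-dimethylphenyl. They therefore offer no size or direction to carry over, and no change beyond the scatter is expected in this assay. The expected outcome is an at least 1.0-fold lower number from compound 3 to compound 4 (0.03 log units; that floor lies within the scatter). The assay may well report only a limit again. For compound 4 the estimated value is 70 ug/mL, with an expected range from 35 ug/mL to 80 ug/mL.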

Compound 4, solubility: > 71 ug/mL
Compound 4 was reported as a limit; the forecaster's own chance of this, stated with the estimate: 70%; middle value at least 1.0-fold (0.00 log units) from the limit.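

In this assay compound 4 is reported only as a limit, as are compound 1, compound 2 and compound 3, so none of the steps from compound 1, compound 2 or compound 3 to compound 4 can be read. The compounds shown leave open where the true values of all four lie, and whether changing the group at this place alters the read-out at all.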